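A methyl on the ring nitrogen of compound 1

The compounds below may be only part of what the source reports. "The series", "measured", "known", "first", "only" and "open" are said of these compounds alone.

Among the compounds with values here, in a functional assay for inhibition, with Homo sapiens as the target (a lower number here means that less compound is needed, a higher number that more compound is needed for the effect), compound 1 `Nc1ccc(C2=NNC(=O)CC2)cc1` gives 46.4 ug/mL, the highest of the three numbers so far. Compound 2 `CCCC(=O)Nc1ccc(C2=NNC(=O)CC2)cc1` gives 1.44 ug/mL, and compound 3 `CCCCC(=O)Nc1ccc(C2=NNC(=O)CC2)cc1` gives 2.64 ug/mL. Both carry a group on a nitrogen on an aromatic ring, and the steps are large: a 32-fold lower number from compound 1 to compound 2 (1.51 log units; beyond the scatter) and an 18-fold lower number from compound 1 to compound 3 (1.24 log units; beyond the scatter). Between those two, a 1.8-fold higher number from compound 2 to compound 3 (0.26 log units; within the scatter) stays within the scatter. Compound 4 `CN1N=C(c2ccc(N)cc2)CCC1=O` instead has methyl in place of hydrogen on an amide-type nitrogen in a ring. Within the data shown here, no measured step touches that place, so the large steps do not carry over and no direction can be read from them. The expected change is a 1.1-fold higher number from compound 1 to compound 4 (0.03 log units; within the scatter), none beyond the scatter, though with wide uncertainty. For compound 4 the estimated value is 50 ug/mL, with an expected range from 12 ug/mL to 200 ug/mL.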

Compound 4, half-maximal effective concentration: > 46.4 ug/mL
Compound 4: no number, only a limit (the forecaster's own chance of this, stated with the estimate: 15%); the middle value is on the limit's open side.
By their numbers in this assay, from the lowest: compounds 2 and 3 (each within the scatter of the next); then compound 1.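

Methyl in place of hydrogen on an amide-type nitrogen in a ring is the only change shown at this position, and in this assay it gives a number no lower from compound 1 to compound 4 (the limit leaves the size open). Unlike the groups on the nitrogen on the aromatic ring, this methyl brings no lower number. Compound 4 has only a limit, not a number: the limit of > 46.4 ug/mL in this assay, at which 1 of the 4 values shown sits.

On these data alone, how far its true value lies past that limit stays open, as does whether a longer chain on this nitrogen would behave like methyl. Also open, as far as these compounds go, is whether methyl here would have the same outcome with the propylcarbonyl group of compound 2 in place.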